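The source may report more compounds than this note shows. Statements on the series, on what has been measured and on what is new or still open speak of the compounds shown alone.

Compound 1 `CC(=O)N(/N=N/c1ccc(Cl)c(C(F)(F)F)c1)c1ccc(Cl)c(C(F)(F)F)c1` — 50600 nM
Compound 2 `CC(=O)N(/N=N/c1ccc([N+](=O)[O-])cc1Br)c1ccc([N+](=O)[O-])cc1Br` — 550 nM
Compound 3 `O=C(c1ccccc1F)N(/N=N/c1ccc([N+](=O)[O-])cc1C(F)(F)F)c1ccc([N+](=O)[O-])cc1C(F)(F)F` — 800 nM

Among these three results in a functional assay on HeLa cells (Homo sapiens) for cytotoxicity, read by MTT assay, with a stated time of 72 h (on this read-out higher numbers stand for weaker inhibition and lower numbers for stronger inhibition), compound 3 has the second highest number. Its nearest neighbour is compound 2, whose number lies within the usual scatter of it, so the two cannot be told apart. Compound 1 lies far higher, well beyond the scatter. Compound 4 `O=C(CCl)N(/N=N/c1ccc([N+](=O)[O-])cc1C(F)(F)F)c1ccc([N+](=O)[O-])cc1C(F)(F)F` has not yet been measured. It differs from compound 3 in one place: chloromethyl in place of 2-fluorophenyl on a carbonyl carbon. Among the compounds with values here, no measured pair shows this exact change, so its effect is uncertain. The expected step of a 1.3-fold lower number from compound 3 to compound 4 (0.12 log units; within the scatter) in this assay is small, because compound 2 gives 550 nM close to compound 3. Compound 4 is therefore estimated at 600 nM, with a likely range from 200 nM to 2500 nM.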

Compound 4, half-maximal inhibitory concentration: 800 nM
Beside the measured number, compound 4's estimate is 1.3-fold (0.12 log units) below it; the range from low to high includes it.
By their numbers in this assay, from the lowest: compounds 2, 3 and 4 (each within the scatter of the next); then compound 1.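

On this carbonyl carbon, chloromethyl in place of 2-fluorophenyl gives no change at the digits printed from compound 3 to compound 4 (within the scatter) in this assay. With the other parts of the molecule held the same, this position therefore tolerates losing the aromatic ring and most of the group's heavy atoms without a detectable shift in the read-out. Nothing available here explains why the two groups read alike. The compounds shown leave open whether an amine or a longer carbon chain on this carbonyl carbon would read the same way. They also leave open whether this swap would behave alike on a different core.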